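The source may hold more compounds than are shown below. What is called first, only, known or untested is meant among the compounds shown, and "the series" means these compounds.

Compound 1 `CC[C@H](c1ccc(C(=O)O)c(Oc2cccc(Cl)c2)c1F)N1CCC[C@H](n2cc(C)c(=O)[nH]c2=O)C1` is the reference point in an ADME assay on a cell-free system (plasma, Homo sapiens) for protein binding, using equilibrium dialysis, with a stated time of 5 h, tested at 10 uM; a lower number here means a smaller unbound share, a higher number a larger unbound share of the compound. Compound 1 gives < 0.01, which is a limit of the assay and not a number. Compound 2 `CC[C@H](c1ccc(C(=O)O)c(Oc2cccc(Cl)c2)c1OC)N1CCC[C@H](n2cc(C)c(=O)[nH]c2=O)C1` gives 0.015 in this assay, and the change there is an at least 1.5-fold higher number from compound 1 to compound 2 (0.17 log units; that floor lies within the scatter). Compound 3 `CCC[C@H](c1ccc(C(=O)O)c(Oc2cccc(Cl)c2)c1F)N1CCC[C@H](n2cc(C)c(=O)[nH]c2=O)C1` gives < 0.01, again a limit. That step is a step that the two limits leave unreadable from compound 1 to compound 3. Compound 4 `CC[C@@H](c1ccc(C(=O)O)c(Oc2cccc(Cl)c2)c1F)N1CCC[C@H](n2cc(C)c(=O)[nH]c2=O)C1` is not yet measured; (the two compounds have the same atoms and bonds and differ only in configuration as drawn: 1 of 2 stereo elements differ; a stereocentre at a saturated chain carbon is drawn R in compound 1 and S in compound 4). Neither measured step concerns a change of configuration, so neither bears directly on it; both point to the limit of < 0.01 in this assay, at which 2 of the 3 values shown sit, where compound 1 sits. The expected step is a step that the limit leaves unreadable from compound 1 to compound 4, nothing beyond the scatter. For compound 4 the estimate is 0.007, between 0.003 and 0.015, most likely again reported as a limit.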

Compound 4, unbound fraction: 0.011
Estimate against measurement, compound 4: 1.6-fold (0.20 log units) below, and the stated range covers the measured number.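

Among the fluoro compounds shown, only the S configuration at the saturated chain carbon gives a number rather than a limit in this assay: compound 4 gives 0.011. Compound 1 gives < 0.01, which is a limit and not a number. As far as these compounds go, the change of configuration therefore gives only a floor, an at least 1.1-fold higher number from compound 1 to compound 4 (0.04 log units; that floor lies within the scatter), so its true size remains unknown.

From the compounds shown here alone, it remains open whether the same change of configuration behaves alike in the methoxy compound. Also open, going by these compounds, is whether a tetrazole in place of the carboxylic acid would move the unbound fraction clear of the limit.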